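From 2-chlorophenyl to 4-methylbenzyl on the amide

A few compounds are considered here, and "the series" means these few. Any claim that something is new, unique, unknown or untested is made for them only; others in the source may bear on it.

Measured in a functional assay on HeLa cells (Homo sapiens) for cytotoxicity, read by MTT assay, with a stated time of 48 h; on this read-out higher numbers stand for weaker inhibition and lower numbers for stronger inhibition:
Compound 1 `CCOC(=O)C1(C(=O)Nc2ccccc2Cl)CC1c1cc(OC)c(OC)c(OC)c1`: 22100 nM; 76400 nM (2 entries)
Compound 2 `CCOC(=O)[C@@]1(C(=O)Nc2ccccc2Cl)C[C@@H]1c1cc(OC)c(OC)c(OC)c1`: > 100000 nM

Compound 2 has only a limit, not a number: > 100000 nM. Compound 3 `CCOC(=O)[C@@]1(C(=O)NCc2ccc(C)cc2)C[C@@H]1c1cc(OC)c(OC)c(OC)c1` carries 4-methylbenzyl in place of 2-chlorophenyl on an amide-type nitrogen. Going by the values given here, no measured pair shows what this change does, so only a modest move towards stronger inhibition in this assay is expected, and compound 3 may also end at the limit. Among the compounds with values here, compound 1 gives the only numbers, 22100 nM; 76400 nM (2 entries), and these guide the expectation. The expected step is an at least 1.6-fold lower number from compound 2 to compound 3 (0.22 log units; that floor lies within the scatter). The estimate for compound 3 is 60000 nM, with an expected range of 15000 nM to 150000 nM.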

Compound 3, half-maximal inhibitory concentration: > 100000 nM
Compound 3 ended at the assay's limit; the forecaster's own chance of this, stated with the estimate: 50%; middle value at least 1.6-fold (0.22 log units) from the limit.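

Going by these compounds alone, compound 2 and compound 3 each give only a limit, not a number, and no step between them can be read. Left open is whether 4-methylbenzyl in place of 2-chlorophenyl on an amide-type nitrogen changes inhibition at all, and in which direction.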